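The source may report more compounds than this note shows. Statements on the series, on what has been measured and on what is new or still open speak of the compounds shown alone.

Measured so far:
compound 1, `O=C(CN(c1nc(Cl)nc2[nH]cnc12)C1CC1)N[C@@H](CC(=O)OCc1ccccc1)C(=O)OCc1ccccc1`, 6.68%
compound 2, `C[C@H](NC(=O)CN(c1nc(Cl)nc2[nH]cnc12)C1CC1)C(=O)O`, 14.7%
compound 3, `NC(=O)CC[C@H](NC(=O)CN(c1ncnc2c1ncn2C1CCCCO1)C1CC1)C(=O)OCc1ccccc1`, 10.7%

In a functional assay on the whole organism (Tail, strain ICR) with Mus musculus as the target, in the tail flick test, with a stated time of 150 min, at a dose of 25 umol/kg by the oral route (a higher number here means a stronger effect of the compound at the dose given, a lower number a weaker effect), compound 3 gives a value that lies within the usual scatter of both compound 2 and compound 1, so the three numbers cannot be ordered with confidence. Compound 4, `O=C(CN(c1ncnc2c1ncn2C1CCCCO1)C1CC1)N[C@@H](CC(=O)OCc1ccccc1)C(=O)OCc1ccccc1`, is not yet measured. It differs from compound 3 in one place: benzyloxycarbonyl in place of carbamoylmethyl on a saturated chain carbon, two bonds along the chain from an amide-type nitrogen and a carbonyl carbon. Going by the values given here, no measured pair shows this change alone, and compound 1, which also carries two benzyloxycarbonyl groups, gives 6.68%. The step of a number 2.7 percentage points lower from compound 3 to compound 4 (within the scatter) is therefore expected to be small, if anything slightly downward, and not beyond the scatter. Compound 4 is estimated at 8%, with a range from 1% to 18%.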

Compound 4, a percentage reported as activity, at one dose (the size of the read-out at that dose, not a potency): 0.06%
Compound 4: the middle estimate sits 7.9 percentage points above what was measured, and the stated range ends above it.
By their numbers in this assay, from the lowest: compounds 4, 1, 3 and 2 (each within the scatter of the next, the first and the last beyond it).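

Placing benzyloxycarbonyl in place of carbamoylmethyl on this saturated chain carbon changes the result in this assay with a number 10.6 percentage points lower from compound 3 to compound 4 (beyond the scatter) as the first readable step at this position. The change is modest, yet it lies beyond the usual scatter, so this position does respond to the group it carries. No measurement offered here accounts for the step.

Going by these compounds, whether the added aromatic ring or the lost carbamoyl group drives the step remains open. So does the result with an amine or a simple methyl ester on this carbon.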